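Aryl swap at the benzylic carbon of compound 2

The compounds below may be only part of what the source reports. "The series", "measured", "known", "first", "only" and "open" are said of these compounds alone.

Compound 2 `CS(=O)(=O)Nc1ccc(C(C(=O)NCc2ccc(C(F)(F)F)nc2SC2CCCCC2)c2cccc(F)c2)cc1F` gives 48.7 nM in an assay on CHO cells for antagonist activity at transient receptor potential cation channel subfamily V member 1 (Homo sapiens), read by FLIPR (a lower number here means a stronger inhibitor, a higher number a weaker inhibitor), the higher of the two numbers at hand in the series. Compound 3 `CC1CCN(c2nc(C(F)(F)F)ccc2CNC(=O)C(c2ccc(F)cc2)c2ccc(NS(C)(=O)=O)c(F)c2)CC1` gives 3.4 nM in this assay, and the gap between the two values lies beyond the scatter; compound 3 differs from compound 2 in several places at once, so the pair only shows that lower numbers are reached within the series. Compound 1 `CS(=O)(=O)Nc1ccc(C(C(=O)NCc2ccc(C(F)(F)F)nc2SC2CCCCC2)C2CCCCC2)cc1F` is reported as "active" (no number reported) in this assay.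

Compound 4 `Cc1ccccc1C(C(=O)NCc1ccc(C(F)(F)F)nc1SC1CCCCC1)c1ccc(NS(C)(=O)=O)c(F)c1` awaits measurement. Against compound 2 it carries 2-methylphenyl in place of 3-fluorophenyl on a saturated chain carbon bound to an aromatic carbon and a carbonyl carbon. Among the measured compounds shown here, no measured pair shows this change by itself, so its size cannot be read from any existing step. Both groups are a six-membered aromatic ring of carbon only with no hydrogen-bond donors or acceptors, and the expectation is a step that stays within the scatter, with no preferred direction. Compound 4 is therefore expected at 55 nM in this assay, with a range of 15 nM to 200 nM. This estimate means an expected step of a 1.1-fold higher number from compound 2 to compound 4 (0.05 log units; within the scatter), inside the usual scatter.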

Compound 4, inhibition constant: "active" (no number reported)
The entry for compound 4 holds no number; there is nothing to compare the estimate with.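

In this assay, among the compounds shown here, compound 4 stands as "active" (no number reported), so no step from compound 2 to it can be read. No supporting data bear on this result. The compounds shown leave open how far 2-methylphenyl in place of 3-fluorophenyl on this carbon moves the inhibition constant.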